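Removing both fluorines from the anilide ring

This account rests on a few compounds, and the source may have more. Where it says the series, first, only, none or still open, it means among the compounds named here.

compound 1 `O=C(Nc1cccc(F)c1)c1cncc(N2CC3CC(C2)N3)c1` gives 0.044 nM in an assay on membranes from Cerebral cortex for displacement of a labelled ligand from Neuronal acetylcholine receptor; alpha4/beta2 (Rattus norvegicus); a higher number here means a weaker inhibitor, a lower number a stronger inhibitor
compound 2 `O=C(Nc1ccc(F)cc1F)c1cncc(N2CC3CC(C2)N3)c1` gives 0.051 nM in this assay

On these two numbers compound 2 and compound 1 cannot be told apart: a 1.2-fold higher number from compound 1 to compound 2 (0.06 log units; within the scatter). Compound 3 `O=C(Nc1ccccc1)c1cncc(N2CC3CC(C2)N3)c1` differs from compound 2 by phenyl in place of 2,4-difluorophenyl on an amide-type nitrogen. For the measured compounds named here, the only step that bears on this, a 1.2-fold higher number from compound 1 to compound 2 (0.06 log units; within the scatter), exchanged one fluorinated ring for another and stayed within the scatter, so for compound 3 no change beyond the scatter is expected in this assay. For compound 3 the estimate is 0.06 nM, ranging from 0.02 nM to 0.2 nM, an expected step of a 1.2-fold higher number from compound 2 to compound 3 (0.07 log units; within the scatter).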

Compound 3, inhibition constant: 1.1 nM
For compound 3 the middle estimate is 18-fold (1.26 log units) below the measured one, and the stated range ends below it.
By their numbers in this assay, from the lowest: compounds 1 and 2 (each within the scatter of the next); then compound 3.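

In this assay the anilide ring proves sensitive to the loss of fluorine: hydrogen in place of the single fluoro gives a 25-fold higher number from compound 1 to compound 3 (1.40 log units; beyond the scatter) and phenyl in place of 2,4-difluorophenyl gives a 22-fold higher number from compound 2 to compound 3 (1.33 log units; beyond the scatter) in the same direction. The earlier step only exchanged one fluorinated ring for another, so it could not show that the unsubstituted phenyl stands apart from both. Nothing measured here accounts for this loss. As far as these compounds go, whether fluoro alone does this or any substituent on the ring would serve stays open; chloro or methyl in its place would bear on that.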